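The source may hold more compounds than are shown below. What is called first, only, known or untested is meant among the compounds shown, and "the series" means these compounds.

In a functional assay on SK-OV-3 cells (Homo sapiens) (a lower number here means a stronger inhibitor of growth, a higher number a weaker inhibitor of growth), compound 1 `O=S(=O)(/C=C/c1ccc(F)cc1)Cc1ccc(Nc2ncnc3ccccc23)cc1` gives 2000 nM and compound 3 `O=S(=O)(/C=C/c1ccc(Br)cc1)Cc1ccc(Nc2ncnc3ccccc23)cc1` gives 1000 nM, and a 2.0-fold lower number from compound 1 to compound 3 (0.30 log units; within the scatter) stays within the scatter. Compound 2 `N#Cc1ccc(/C=C/S(=O)(=O)Cc2ccc(Nc3ncnc4ccccc34)cc2)cc1` has only a limit, > 100000 nM, and no number.

Compound 4 `O=S(=O)(/C=C/c1ccc(F)cc1Cl)Cc1ccc(Nc2ncnc3ccccc23)cc1` differs from compound 2 by 2-chloro-4-fluorophenyl in place of 4-cyanophenyl on a double-bonded chain carbon bound to a double-bonded chain carbon: 2-chloro-4-fluorophenyl in place of 4-cyanophenyl on a double-bonded chain carbon. Among the measured compounds shown here, the steps that bear on this are an at least 50-fold higher number from compound 1 to compound 2 (1.69 log units; beyond the scatter) and an at least 100-fold lower number from compound 2 to compound 3 (2.00 log units; beyond the scatter), both large and beyond the scatter. For the measured compounds named here, compound 4 loses the cyano and carries the fluoro of compound 1, but no measured step covers the added chloro.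

A large step to a lower number is therefore expected, an at least 66-fold lower number from compound 2 to compound 4 (1.82 log units; beyond the scatter). For compound 4 the estimated value is 1500 nM, with an expected range of 400 nM to 8000 nM.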

Compound 4, concentration for 50% growth inhibition: 44000 nM
Estimate against measurement, compound 4: 29-fold (1.47 log units) below; the whole stated range lies below it.
By their numbers in this assay, from the lowest: compounds 3 and 1 (each within the scatter of the next); then compound 4. At a limit, above all of these: compound 2.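

Adding chloro to the aromatic ring of compound 1 is a large change in this assay: a 22-fold higher number from compound 1 to compound 4 (1.34 log units; beyond the scatter) is beyond the scatter, whereas the earlier swap of fluoro for bromo was not. The 2-chloro-4-fluorophenyl group also falls well short of 4-bromophenyl, with a 44-fold higher number from compound 3 to compound 4 (1.64 log units; beyond the scatter) as the step, so a halogen-bearing ring at this place does not by itself preserve growth inhibition. Only a bound can be read for the change from 4-cyanophenyl, as an at least 2.2-fold lower number from compound 2 to compound 4 (0.35 log units; beyond the scatter) rests on a limit: the limit of > 100000 nM in this assay, at which 1 of the 4 values shown sits.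

Going by these compounds, whether chloro without the fluoro gives the same large step stays open. So does the effect of a methoxy or an amine on this ring.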